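The source may hold more compounds than are shown below. What is called first, only, known or untested is meant among the compounds shown, and "the series" means these compounds.

Measured so far:

Compound 1 `CCCNC(=O)Nc1nc2ccc(-c3cnc(OC)c(NS(=O)(=O)c4ccc(F)cc4)c3)cn2n1` gives 420 nM in a functional assay on U-87MG ATCC cells for cytotoxicity against U-87 MG (Homo sapiens), read by MTT assay, with a stated time of 72 h; a higher number here means a weaker inhibitor, a lower number a stronger inhibitor.
Compound 2 `COc1ncc(-c2ccc3nc(NC(=O)NCCN4CCCC4)nn3c2)cc1NS(=O)(=O)c1ccc(F)cc1` gives 1120 nM in this assay.
Compound 3 `COc1ncc(-c2ccc3nc(NC(=O)NC4CC4)nn3c2)cc1NS(=O)(=O)c1ccc(F)cc1` gives 540 nM in this assay.

Compound 2 has the highest number of the three and is therefore the weakest inhibitor here: the step of a 2.7-fold higher number from compound 1 to compound 2 (0.43 log units; beyond the scatter) and the step of a 2.1-fold lower number from compound 2 to compound 3 (0.32 log units; beyond the scatter) both lie beyond the scatter, so its position is not an artefact of repeat variation. Compounds 1 and 3 carry only small groups on the amide-type nitrogen, and the step of a 1.3-fold higher number from compound 1 to compound 3 (0.11 log units; within the scatter) between them is within the scatter.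

Compound 4 `COc1ncc(-c2ccc3nc(NC(=O)NCC(=O)N4CCCC4)nn3c2)cc1NS(=O)(=O)c1ccc(F)cc1` differs from compound 2 in one place: (pyrrolidin-1-yl)carbonyl in place of (pyrrolidin-1-yl)methyl on a saturated chain carbon bound to an amide-type nitrogen. The pyrrolidine ring is kept, but it is now joined through a (pyrrolidin-1-yl)carbonyl rather than a (pyrrolidin-1-yl)methyl. Within the data shown here, no measured step tests exactly this exchange. What the measured steps show is that adding 2-(pyrrolidin-1-yl)ethyl to the small-group compounds raised the number modestly; whether changing the link to the ring recovers part of that loss cannot be read from the three values. The expectation is therefore a small step in this assay, most likely within the scatter and, if anything, toward a lower number. Compound 4 is expected to give about 850 nM, with a range from 350 nM to 2000 nM, which means an estimated step of a 1.3-fold lower number from compound 2 to compound 4 (0.12 log units; within the scatter).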

Compound 4, half-maximal inhibitory concentration: 1000 nM
Beside the measured number, compound 4's estimate is 1.2-fold (0.07 log units) below it, within the range that was stated.
By their numbers in this assay, from the lowest: compounds 1, 3, 4 and 2 (each within the scatter of the next, the first and the last beyond it).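

In this assay, replacing (pyrrolidin-1-yl)methyl with (pyrrolidin-1-yl)carbonyl on a saturated chain carbon bound to an amide-type nitrogen gives a 1.1-fold lower number from compound 2 to compound 4 (0.05 log units; within the scatter), so the earlier result for compound 2 is not shown to depend on whether a carbonyl links the pyrrolidine ring to the chain. The new group also gives a 1.9-fold higher number from compound 3 to compound 4 (0.27 log units; within the scatter), which cannot be told apart from the scatter, but it gives a 2.4-fold higher number from compound 1 to compound 4 (0.38 log units; beyond the scatter), which lies beyond the scatter, so the small propyl group remains distinguishable from this larger ring-bearing group while the cyclopropyl group does not. No measurement accompanies these compounds that could explain any of these readings.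

The compounds shown leave open whether the pyrrolidine ring itself matters, a question that a morpholine ring or a dimethylamino group in its place, on the same chain, could begin to answer. They also leave open how the reading would respond to a longer chain between the amide-type nitrogen and the carbonyl, or to a simple butyl chain carrying no ring at all.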